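Para substituent variation on the aryl group: methyl to bromo

A few compounds are considered here, and "the series" means these few. Any claim that something is new, unique, unknown or untested is made for them only; others in the source may bear on it.

Of the compounds shown here, two carry a number so far. Compound 1 `CC(=O)OC[C@H]1O[C@H](OC[C@@H](Cn2cc(CN(c3nc(-c4ccc([N+](=O)[O-])cc4)no3)C3CCCCC3)nn2)OC(C)=O)C=C[C@@H]1OC(C)=O` gives 64.1 ug/mL in an ADME assay on RAW264.7 cells (Mus musculus) for cytotoxicity, read by MTT assay, with a stated time of 48 h; on this read-out lower numbers stand for higher toxicity in this test and higher numbers for lower toxicity in this test. Compound 2 `CC(=O)OC[C@H]1O[C@H](OC[C@@H](Cn2cc(CN(c3nc(-c4ccc(C)cc4)no3)C3CCCCC3)nn2)OC(C)=O)C=C[C@@H]1OC(C)=O` gives 45.3 ug/mL in this assay. The step of a 1.4-fold lower number from compound 1 to compound 2 (0.15 log units; within the scatter) lies within the scatter, so on the two numbers to hand compound 2 sits beside compound 1 rather than apart from it; nothing separates the two beyond repeat variation.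

Compound 3 `CC(=O)OC[C@H]1O[C@H](OC[C@@H](Cn2cc(CN(c3nc(-c4ccc(Br)cc4)no3)C3CCCCC3)nn2)OC(C)=O)C=C[C@@H]1OC(C)=O` awaits measurement. It differs from compound 2 by bromo in place of methyl on an aromatic carbon. Among the compounds with values here, the one measured step at this position is a 1.4-fold lower number from compound 1 to compound 2 (0.15 log units; within the scatter), which did not leave the scatter; no step introducing bromo at this position has been measured. The expectation for this assay is therefore a step of no size beyond the scatter, with no set direction. Compound 3 is expected to give 48 ug/mL, with a range from 25 ug/mL to 95 ug/mL. The step of a 1.1-fold higher number from compound 2 to compound 3 (0.03 log units; within the scatter) that this estimate means is expected to stay within the scatter.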

Compound 3, half-maximal cytotoxic concentration: 39.1 ug/mL
For compound 3 the middle estimate is 1.2-fold (0.09 log units) above the measured one; measured number inside the range.
By their numbers in this assay, from the lowest: compounds 3, 2 and 1 (each within the scatter of the next).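

In this assay, bromo in place of methyl on the aromatic carbon para to a large group gives a 1.2-fold lower number from compound 2 to compound 3 (0.06 log units; within the scatter), and bromo in place of nitro at the same carbon gives a 1.6-fold lower number from compound 1 to compound 3 (0.21 log units; within the scatter). With a third group now read at this position, even the widest step among the three stays within the scatter, so nitro, methyl and bromo cannot be ranked here, and the earlier single step no longer stands alone: the series now shows three substituents at this carbon that are not told apart by this read-out. No measurement is available that would explain why these numbers stay so close together.

As far as these compounds go, it remains open whether a group of another kind on this aromatic carbon, such as an amine, a carboxylic acid or a longer chain, would produce a step beyond the scatter, or whether the numbers would stay together as they do for these three. Also open, from the compounds shown here alone, is whether bromo would give the same picture on another carbon of this ring, or with a change elsewhere in the shared core.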